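Swapping an Aryl Amine for a Benzyl Amine

The source may hold more compounds than are shown below. What is called first, only, known or untested is meant among the compounds shown, and "the series" means these compounds.

Compound 2 `Cc1ccc(Cl)cc1Nc1nc(C(F)(F)F)ccc1CNC(=O)C(C)c1ccc(NS(C)(=O)=O)c(F)c1` gives 140 nM in a functional assay on CHO-K1 cells for antagonist activity at transient receptor potential cation channel subfamily V member 1 (Homo sapiens), read by FLIPR (a lower number here means a stronger inhibitor, a higher number a weaker inhibitor), the lowest of the two numbers measured, while compound 1 `CC1CCC(Nc2nc(C(F)(F)F)ccc2CNC(=O)C(C)c2ccc(NS(C)(=O)=O)c(F)c2)CC1` gives 1130 nM. For the measured compounds named here, the one measured step, an 8.1-fold lower number from compound 1 to compound 2 (0.91 log units; beyond the scatter), concerns a different change. Compound 3 `CC(C(=O)NCc1ccc(C(F)(F)F)nc1NCc1ccc(Cl)cc1)c1ccc(NS(C)(=O)=O)c(F)c1` differs from compound 2 by 4-chlorobenzyl in place of 5-chloro-2-methylphenyl on a nitrogen on an aromatic ring. Going by the values given here, no measured step covers this rearrangement, so the expectation rests on little. A modest weakening is expected, a 2.9-fold higher number from compound 2 to compound 3 (0.46 log units; beyond the scatter). Compound 3 is therefore estimated at 400 nM in this assay, within a range of 100 nM to 2000 nM.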

Compound 3, half-maximal inhibitory concentration: 414 nM
Beside the measured number, compound 3's estimate is 1.0-fold (0.01 log units) below it, within the range that was stated.
By their numbers in this assay, from the lowest: compound 2; then compound 3; then compound 1.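

In this assay, the 4-chlorobenzyl group on this nitrogen sits in the middle: a 3.0-fold higher number from compound 2 to compound 3 (0.47 log units; beyond the scatter) shows a loss against the 5-chloro-2-methylphenyl group, while a 2.7-fold lower number from compound 1 to compound 3 (0.44 log units; beyond the scatter) shows a gain over 4-methylcyclohexyl. An aromatic ring held one carbon away from the nitrogen therefore still beats the saturated ring here, though it does not match the directly attached aromatic ring. Nothing measured explains this order.

The step changes the link and the ring's substituents together, so their shares remain unseparated. A 5-chloro-2-methylbenzyl group would keep the substituents and change only the link.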